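The source may hold more compounds than are shown below. What is called first, only, known or untested is meant among the compounds shown, and "the series" means these compounds.

Compound 1 `Cc1ccc(-c2nn(-c3ccc(Cl)cc3)cc2C=O)cc1` has been tested in a functional assay on the whole organism (strain Wistar albino) for inhibition, with Rattus norvegicus as the target, read by paw edema, with stated times of 1 h and 2 h, at a dose of 0.32 mmol/kg by the intraperitoneal route (on this read-out lower numbers stand for less inhibition and higher numbers for more inhibition at the one dose given (going by the name of the read-out)), where compound 1 gives 49.9%. Its only companion so far, compound 2 `Cc1ccc(-c2nn(-c3ccc(S(N)(=O)=O)cc3)cc2C=O)cc1`, gives 58.4%, and the step of a number 8.5 percentage points higher from compound 1 to compound 2 (within the scatter) does not separate the two. Compound 3 `Cc1ccc(-c2nn(-c3ccc(Cl)cc3)cc2/C=N\c2ccccc2)cc1` changes compound 1 elsewhere: a group of 8 heavy atoms (7 carbon, 1 nitrogen; one six-membered aromatic ring of carbon only) in place of a group of 2 heavy atoms (1 carbon, 1 oxygen; no ring), on an aromatic carbon. Within the data shown here, no measured step touches the formyl group, and the one known step, chloro to sulfamoyl, stayed within the scatter, so the data give no direction. The step of a number 0.1 percentage points higher from compound 1 to compound 3 (within the scatter) is therefore expected to be none beyond the scatter, and compound 3 is estimated at 50%, with a range from 35% to 65%.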

Compound 3, a percentage reported as inhibition, in the whole organism at one dose (the size of the read-out at that dose, not a potency): 40.1%
Beside the measured number, compound 3's estimate is 9.9 percentage points above it; the range from low to high includes it.
By their numbers in this assay, from the lowest: compounds 3, 1 and 2 (each within the scatter of the next, the first and the last beyond it).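

In this assay, among these compounds, this is the first change at the aromatic carbon that carries the formyl group, and swapping formyl for a group of 8 heavy atoms with a six-membered aromatic ring gives a number 9.8 percentage points lower from compound 1 to compound 3 (within the scatter). So even this large a replacement at that position does not move the number past the usual scatter. No measurement shown here bears on why.

Still open, as far as these compounds go, is whether a carboxylic acid or an amine at this carbon would give a step beyond the scatter. Also open, from the compounds shown here alone, is how the larger group behaves alongside the sulfamoyl of compound 2.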